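Replacing 4-aminophenyl with 1H-indol-6-yl at the limit

The source may report more compounds than this note shows. Statements on the series, on what has been measured and on what is new or still open speak of the compounds shown alone.

In a functional assay on MCF7 cells (Homo sapiens) for antiproliferative activity, read by MTT assay, with a stated time of 48 h (on this read-out lower numbers stand for stronger inhibition and higher numbers for weaker inhibition), compound 1 (`COc1cc(-c2cccc3nc(-c4ccc(Br)cc4)oc23)cc(OC)c1OC`) gives > 25000 nM as its result, and this is a limit of the assay. Compound 2 (`COc1cc(-c2cccc3nc(-c4ccc(N)cc4)oc23)cc(OC)c1OC`) gives > 25000 nM as its result, which is also a limit. It therefore stands at the limit of > 25000 nM in this assay, at which 2 of the 2 values shown sit, and has no number of its own. The next compound, compound 3 (`COc1cc(-c2cccc3nc(-c4ccc5cc[nH]c5c4)oc23)cc(OC)c1OC`), has not yet been measured. The change from compound 2 is 1H-indol-6-yl in place of 4-aminophenyl on an aromatic carbon and places 1H-indol-6-yl in place of 4-aminophenyl on an aromatic carbon. For the measured compounds named here, the one measured step that bears on this is a step that the two limits leave unreadable from compound 1 to compound 2 and it offers no size to carry over. In this assay the expectation is therefore of no firm shift, with weak inhibition the likely outcome and another limit quite possible. The estimated step is an at least 1.2-fold lower number from compound 2 to compound 3 (0.09 log units; that floor lies within the scatter) and its direction is uncertain. For compound 3 the estimated value is 20000 nM (2000 nM to 60000 nM).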

Compound 3, half-maximal inhibitory concentration: > 25000 nM
Compound 3: only a limit was reported (the forecaster's own chance of this, stated with the estimate: 60%); middle value at least 1.2-fold (0.09 log units) from the limit.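

Compound 3 joins compound 1 and compound 2 at a limit and has no number of its own, so no step among these compounds can be read: the limit of > 25000 nM in this assay, at which 3 of the 3 values shown sit. The compounds shown leave open whether any group at this place on the shared core gives a measurable inhibition.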